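The compounds below may be only part of what the source reports. "The series", "measured", "known", "first", "only" and "open" are said of these compounds alone.

Compound 1 `N#Cc1c(N)cccc1[S+]([O-])c1ccccc1Br` and compound 3 `N#Cc1ccccc1[S+]([O-])c1cccc(N)c1C#N` share a core and differ in one place, described as cyano in place of bromo on an aromatic carbon. In a functional assay on MT4 cells (Homo sapiens) for cytotoxicity (on this read-out higher numbers stand for weaker inhibition and lower numbers for stronger inhibition), compound 1 gives 168000 nM. In this assay compound 3 gives > 200000 nM, which is a limit of the assay and not a number. Taken together the two readings give an at least 1.1-fold higher number from compound 1 to compound 3 (0.07 log units; that floor lies within the scatter). Compound 2 `N#Cc1c(N)cccc1[S+]([O-])c1ccc(Br)cc1` is built from the same atoms as compound 1, joined differently; the difference between the two cores is not broken down here. In this assay compound 2 gives > 200000 nM, again a limit of the assay rather than a number. The picture is shaped by the limit of > 200000 nM in this assay, at which 2 of the 3 values shown sit, so most of what is known sets a floor rather than a value.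

Compound 4 `N#Cc1ccc([S+]([O-])c2cccc(N)c2C#N)cc1` has not been measured. It differs from compound 2 as cyano in place of bromo on an aromatic carbon. For the measured compounds named here, this is the same kind of change as the one from compound 1 to compound 3, but not the same: in compound 3 the cyano sits ortho to a large group, in compound 4 it sits para to a large group. For compound 4 the expected step is a step that the limit leaves unreadable from compound 2 to compound 4, resting on compound 1 moving to compound 3 by an at least 1.1-fold higher number from compound 1 to compound 3 (0.07 log units; that floor lies within the scatter) and on compound 2 giving only a limit, > 200000 nM. Compound 4 is therefore estimated at 300000 nM, between 150000 nM and 600000 nM, most likely reported only as a limit.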

Compound 4, half-maximal inhibitory concentration: > 200000 nM
Compound 4: no number, only a limit; the forecaster's own chance of this, stated with the estimate: 80%; the middle value does not contradict the limit.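

No size can be read for the change from compound 2 to compound 4, cyano in place of bromo on an aromatic carbon, because both readings are limits of the assay and not numbers: the limit of > 200000 nM in this assay, at which 3 of the 4 values shown sit. The compounds shown leave open where the true values of compound 2, compound 3 and compound 4 lie in this assay and whether this change alters the number at all.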